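Aryl amine swap on the acrylamide series

The source may hold more compounds than are shown below. What is called first, only, known or untested is meant among the compounds shown, and "the series" means these compounds.

Among the compounds with values here, compound 2 `C=CC(=O)Nc1cccc(NC(=O)CSc2nc(Nc3cccc(Br)c3)c3ccccc3n2)c1` gives 12100 nM in a functional assay on NCI-H1975 cells (Homo sapiens) for inhibition, read by MTT assay, with a stated time of 72 h; a lower number here means a stronger inhibitor, a higher number a weaker inhibitor; only one other number exists here, and compound 1 `O=C(CSc1nc(Nc2ccccc2)c2ccccc2n1)Nc1ccc(Cl)c(Cl)c1` gives 10400 nM in this assay, which lies within the scatter of compound 2, so neither stands apart. Compound 3 `C=CC(=O)Nc1cccc(NC(=O)CSc2nc(Nc3ccc(Cl)cc3Cl)c3ccccc3n2)c1` differs from compound 2 by 2,4-dichlorophenyl in place of 3-bromophenyl on a nitrogen on an aromatic ring. Within the data shown here, no measured pair shows this change, and the two measured compounds sit close together while differing in two places. The step of a 1.2-fold lower number from compound 2 to compound 3 (0.08 log units; within the scatter) is therefore expected to be small, probably none beyond the scatter. For compound 3 the estimate is 10000 nM, with a range of 4000 nM to 30000 nM.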

Compound 3, half-maximal inhibitory concentration: 5990 nM
Beside the measured number, compound 3's estimate is 1.7-fold (0.22 log units) above it; the measured number falls inside the stated range.
By their numbers in this assay, from the lowest: compounds 3, 1 and 2 (each within the scatter of the next, the first and the last beyond it).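

Within the data shown here, on the aryl group at the nitrogen on an aromatic ring, 2,4-dichlorophenyl in place of 3-bromophenyl gives a 2.0-fold lower number from compound 2 to compound 3 (0.31 log units; beyond the scatter) in this assay, the only step so far and a modest one. This position therefore responds to the choice of aryl group while the acrylamide side stays unchanged. Nothing available explains the step.

Still open, on these data alone, is whether either chlorine alone, as 2-chlorophenyl or 4-chlorophenyl, accounts for the step. As far as these compounds go, it is also open how a ring carrying an amine or a carboxylic acid would read at this position.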